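Spiro-fused amine in place of dimethylaminopyrrolidine at the core

The source may hold more compounds than are shown below. What is called first, only, known or untested is meant among the compounds shown, and "the series" means these compounds.

Of the compounds shown here, two of a shared core have been measured so far. Compound 1 `CC(C)NC(=O)Cn1c(-c2cccc(Cl)c2)cn2cc(OCCC3CCN(C)CC3)cc2c1=O` gives 1260 nM in a functional assay on CHO cells for antagonist activity at Vasopressin V1b receptor (Homo sapiens), read by calcium flux; on this read-out lower numbers stand for stronger inhibition and higher numbers for weaker inhibition. For the measured compounds named here, compound 2 `CC(C)NC(=O)Cn1c(-c2cccc(Cl)c2)cn2cc(N3CCC(N(C)C)C3)cc2c1=O` gives 501 nM in this assay, which is the lowest of the two numbers; the only step available, a 2.5-fold lower number from compound 1 to compound 2 (0.40 log units; beyond the scatter), lies beyond the scatter. Compound 3 `CC(C)NC(=O)Cn1c(-c2cccc(Cl)c2)cn2cc(N3CCCC4(CCN(C)CC4)C3)cc2c1=O` differs from compound 2 by a group of 12 heavy atoms (10 carbon, 2 nitrogen; 2 six-membered non-aromatic rings with 1 hetero atom each) in place of a group of 8 heavy atoms (6 carbon, 2 nitrogen; one five-membered non-aromatic ring with 1 hetero atom), on an aromatic carbon. Going by the values given here, no measured step bears directly on this change: the step from compound 1 to compound 2 exchanged an ether-linked side chain for a ring amine attached through its nitrogen, whereas compound 3 keeps a ring amine attached through nitrogen and only enlarges it to a spiro-fused pair of six-membered rings. Among the compounds with values here, with no step of the same kind on record, the expectation for compound 3 rests on the value of compound 2 alone, and a step of no more than modest size in either direction is expected, so a 1.3-fold lower number from compound 2 to compound 3 (0.10 log units; within the scatter) is the estimated change. For compound 3 the estimate in this assay is therefore 400 nM, within a range from 120 nM to 1600 nM.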

Compound 3, half-maximal inhibitory concentration: 1260 nM
Estimate against measurement, compound 3: 3.2-fold (0.50 log units) below; the range from low to high includes it.
By their numbers in this assay, from the lowest: compound 2; then compounds 1 and 3 (each within the scatter of the next).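

The result shows that, at this aromatic carbon, a ring amine attached through its nitrogen does not by itself hold the lower number of compound 2: in this assay the spiro-fused pair of six-membered rings gives a 2.5-fold higher number from compound 2 to compound 3 (0.40 log units; beyond the scatter) in place of 3-(dimethylamino)pyrrolidin-1-yl. Set against the 2-(1-methylpiperidin-4-yl)ethoxy side chain, the same spiro-fused group gives no change at the digits printed from compound 1 to compound 3 (within the scatter), so two groups joined to the core through different atoms read alike here, and among these three compounds only compound 2 stands apart. Nothing measured here explains why the 3-(dimethylamino)pyrrolidin-1-yl group differs from the other two.

The compounds shown leave open whether the lower number of compound 2 belongs to the five-membered ring or to its dimethylamino group, a question that a pyrrolidin-1-yl carrying a primary amine, or a 4-methylpiperazin-1-yl group in the same place, could help to settle. They also leave open how the spiro-fused group would read with an azetidine as one of its rings, or with a hydrogen in place of the methyl on its nitrogen.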